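Biphenyl variant of a limit-bound sulfonylamidine series

A few compounds are considered here, and "the series" means these few. Any claim that something is new, unique, unknown or untested is made for them only; others in the source may bear on it.

Measured compounds:
compound 1 `O=S(=O)(NC1=NCCN1C(=S)SN1CCn2c1nsc2=S)c1ccccc1`
compound 2 `COc1ccc(OC)c(S(=O)(=O)NC2=NCCN2C(=S)SN2CCn3c2nsc3=S)c1`
compound 3 `COc1ccc(S(=O)(=O)NC2=NCCN2C(=S)SN2CCn3c2nsc3=S)cc1OC`

In a functional assay on KYSE-510 cells (Homo sapiens) for antiproliferative activity, read by crystal violet staining, with a stated time of 96 h (a lower number here means a stronger inhibitor of growth, a higher number a weaker inhibitor of growth), compound 1 gives only a limit, >= 20000 nM. Compound 2 likewise gives a limit, >= 20000 nM. Compound 3 also gives a limit, >= 20000 nM. The steps a step that the two limits leave unreadable from compound 1 to compound 2 and a step that the two limits leave unreadable from compound 1 to compound 3 are therefore unreadable, and so is a step that the two limits leave unreadable from compound 2 to compound 3; what is shared is the limit of >= 20000 nM in this assay, at which 3 of the 3 values shown sit.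

Compound 4 `O=S(=O)(NC1=NCCN1C(=S)SN1CCn2c1nsc2=S)c1ccc(-c2ccccc2)cc1` differs from compound 1 by phenyl in place of hydrogen on an aromatic carbon. Going by the values given here, no measured step varies this position, so nothing among the measured compounds points to a gain. Compound 4 is expected to give 20000 nM with a range of 7000 nM to 60000 nM, most likely again reported only as a limit. The estimated step of a number no higher from compound 1 to compound 4 (the limit leaves the size open) is thus expected to be none beyond the scatter.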

Compound 4, concentration for 50% growth inhibition: >= 20000 nM
Compound 4: no number, only a limit (the forecaster's own chance of this, stated with the estimate: 80%); the middle value sits exactly at the limit.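

In this assay compound 4 gives >= 20000 nM, a limit and not a number. The step from compound 1 to compound 4 therefore cannot be read: the limit of >= 20000 nM in this assay, at which 4 of the 4 values shown sit. Going by these compounds, whether phenyl in place of hydrogen changes growth inhibition at all remains open.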